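The source may hold more compounds than are shown below. What is called first, only, known or untested is meant among the compounds shown, and "the series" means these compounds.

Compound 1 `COc1cc(CNc2nc3cc(N)cc(N)c3nc2-c2ccccc2)cc(OC)c1OC` and compound 2 `COc1ccc(Sc2nc3cc(N)cc(N)c3nc2-c2ccccc2)cc1` share a core and differ in the linker to the outer aromatic ring. In a functional assay on MDA-MB-435 cells (Homo sapiens) for inhibition, read by sulforhodamine B assay, with a stated time of 48 h (a higher number here means a weaker inhibitor of growth, a lower number a stronger inhibitor of growth), compound 1 gives 912 nM. For compound 2 this assay reports only a limit, < 100000 nM, and no number. Compound 3 `Nc1cc(N)c2nc(-c3ccccc3)c(Sc3ccc(F)cc3)nc2c1` differs from compound 2 by fluoro in place of methoxy on an aromatic carbon. For the measured compounds named here, with no measured step of this kind to lean on, the expected step from compound 2 to compound 3 in this assay is small, a step that the limit leaves unreadable from compound 2 to compound 3, within the usual scatter. Compound 3 is therefore estimated at 25000 nM, between 3000 nM and 100000 nM.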

Compound 3, concentration for total growth inhibition: 33100 nM
Beside the measured number, compound 3's estimate is 1.3-fold (0.12 log units) below it, within the range that was stated.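

For the compounds shown here, no step from compound 2 to compound 3 can be read in this assay, since compound 2 carries only a limit: the limit of < 100000 nM in this assay, at which 1 of the 3 values shown sits. The compounds shown leave open what fluoro in place of methoxy on an aromatic carbon does to the value in this assay.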